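The source may report more compounds than this note shows. Statements on the series, on what has been measured and on what is new or still open speak of the compounds shown alone.

Compound 1, `CCc1ccc(-c2ccc(-c3ccc(C(=N)N)cc3)o2)cc1`, in an assay on isolated protein for inhibition of ribosyldihydronicotinamide dehydrogenase [quinone] (Homo sapiens), read by spectrophotometry, with a stated time of 1 min; a lower number here means a stronger inhibitor, a higher number a weaker inhibitor: 312 nM
Compound 2, `N=C(N)c1ccc(-c2ccc(-c3ccc([N+](=O)[O-])cc3)o2)cc1`: 24 nM
Compound 3, `N=C(N)c1ccc(-c2ccc(-c3cccc([N+](=O)[O-])c3)o2)cc1`: 28 nM

Among these three, compound 2 and compound 3 cannot be told apart, since their numbers in this assay lie within the usual scatter of each other; both sit far below compound 1, so compound 2 stands at the low end of what has been measured. Compound 4, `CC(C)(C)c1ccc(-c2ccc(-c3ccc(C(=N)N)cc3)o2)cc1`, differs from compound 2 in one place: tert-butyl in place of nitro on an aromatic carbon. Within the data shown here, one measured step bears on this change. Going from compound 1 to compound 2, ethyl gave way to nitro and the number fell sharply: a 13-fold lower number from compound 1 to compound 2 (1.11 log units; beyond the scatter). Compound 4 goes the other way, removing the nitro again and putting tert-butyl there. Tert-butyl is not ethyl, and no measured pair sets tert-butyl against ethyl, so the exact size is uncertain; still, a rise back toward the number of compound 1, 312 nM, is the expectation that the one relevant step supports. Compound 4 is therefore expected to show a step of a 13-fold higher number from compound 2 to compound 4 (1.10 log units; beyond the scatter), landing at an estimated 300 nM, with a range from 100 nM to 1000 nM.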

Compound 4, half-maximal inhibitory concentration: 712 nM
The estimate for compound 4 lay 2.4-fold (0.38 log units) below the measured number; measured number inside the range.
By their numbers in this assay, from the lowest: compounds 2 and 3 (each within the scatter of the next); then compound 1; then compound 4.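

In this assay, the new compound shows that the cost of losing nitro at this aromatic carbon is not tied to ethyl alone: putting tert-butyl there gives a 30-fold higher number from compound 2 to compound 4 (1.47 log units; beyond the scatter), so a second carbon-only group also lands far from the nitro compound. The two carbon-only groups are not interchangeable at this place either, since tert-butyl in place of ethyl gives a 2.3-fold higher number from compound 1 to compound 4 (0.36 log units; beyond the scatter), a modest step but one that lies beyond the scatter, so the number depends on which of these groups is present and not just on the absence of nitro. No measurement at hand explains why these groups give such different numbers.

The compounds shown leave open whether the low numbers belong to nitro alone or could also be reached at this place with other groups, such as an amine, a nitrile or a carboxylic acid. Compound 3 also carries nitro, placed differently on the ring, and whether swapping its nitro for tert-butyl would give a step of similar size remains an open question.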